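Swapping the Aryl Group in a Cytotoxicity Series

A few compounds are considered here, and "the series" means these few. Any claim that something is new, unique, unknown or untested is made for them only; others in the source may bear on it.

Compound 1 `COc1ccc(C2C(C#N)=C(N)N(c3cc(OC)c(OC)c(OC)c3)C3=C2C(=O)CC(C)(C)C3)cc1` has been tested in a functional assay on Ehrlich cells (Mus musculus) for cytotoxicity, tested at 50 ug/mL (on this read-out higher numbers stand for a stronger effect at the one concentration tested and lower numbers for a weaker effect), where compound 1 gives 11%. Among the measured compounds shown here, of the two numbers available, compound 1 stands at the top, though only within the scatter of its one neighbour: compound 2 `COc1cc(N2C(N)=C(C#N)C(c3c(OC)ccc4ccccc34)C3=C2CC(C)(C)CC3=O)cc(OC)c1OC` gives 10% in this assay, and a number 1 percentage points lower from compound 1 to compound 2 (within the scatter). For the measured compounds named here, compound 2 differs from compound 1 by 2-methoxynaphthalen-1-yl in place of 4-methoxyphenyl on a saturated ring carbon, so the single step on record says that exchanging this aryl group barely moved the read-out.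

Compound 3 `COc1cc(N2C(N)=C(C#N)C(c3ccccc3Cl)C3=C2CC(C)(C)CC3=O)cc(OC)c1OC` has not yet been measured. Against compound 1 it carries the following difference: 2-chlorophenyl in place of 4-methoxyphenyl on a saturated ring carbon The exchange again sits on the saturated ring carbon. Going by the values given here, the step from compound 1 to compound 2 is the only measured step that bears on it, and that step stayed within the scatter. From the compounds shown here alone, a 2-chlorophenyl group itself is untested in this assay, so the comparison is loose. Still, the expected outcome is no step beyond the scatter, no change at the digits printed from compound 1 to compound 3 (within the scatter). Compound 3 is therefore estimated at 11%, with a range from 2% to 26%.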

Compound 3, a percentage reported as activity, at one concentration (the size of the read-out at that concentration, not a potency): 20%
Beside the measured number, compound 3's estimate is 9 percentage points below it, and the stated range covers the measured number.
By their numbers in this assay, from the lowest: compounds 2, 1 and 3 (each within the scatter of the next).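

Compound 3 brings a third aryl group to the saturated ring carbon, with a chlorine-bearing ring taking the place of the methoxy-bearing rings of the earlier pair, and in this assay this gives a number 9 percentage points higher from compound 1 to compound 3 (within the scatter) and a number 10 percentage points higher from compound 2 to compound 3 (within the scatter) on the same read-out. Among the compounds shown here, the earlier pair showed only that one methoxy-bearing aryl group could stand in for another, whereas these steps extend that to a group with no methoxy at all, so 4-methoxyphenyl, 2-methoxynaphthalen-1-yl and 2-chlorophenyl cannot be ranked at this position. No measurement on hand accounts for these numbers.

From the compounds shown here alone, all three groups at this position are aromatic rings of carbon only, so it remains open whether a saturated cyclohexyl ring, a pyridine ring or a phenyl ring carrying a carboxylic acid or an amine would give a step beyond the scatter. The 3,4,5-trimethoxyphenyl, cyano and amino groups are the same in all three compounds, which leaves their part in the read-out unknown, and a change at any of those places could behave quite differently from a change at this carbon.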